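Aryl groups on the methyl of compound 1

A few compounds are considered here, and "the series" means these few. Any claim that something is new, unique, unknown or untested is made for them only; others in the source may bear on it.

Compound 1 `CCOC(=O)c1ccc(-c2nn(C)c3ccccc23)cc1` gives 270 nM in a functional assay on cells (Platelet, Homo sapiens) for inhibition (on this read-out higher numbers stand for weaker inhibition and lower numbers for stronger inhibition), the highest of the three numbers seen so far. Compound 2 `CCOC(=O)c1ccc(-c2nn(Cc3ccc(Cl)cc3)c3ccccc23)cc1` gives 120 nM and compound 3 `CCOC(=O)c1ccc(-c2nn(Cc3ccc(F)cc3)c3ccccc23)cc1` gives 190 nM. Compound 4 `CCOC(=O)c1ccc(-c2nn(Cc3ccncc3)c3ccccc23)cc1` differs from compound 1 by pyridin-4-yl in place of hydrogen on a saturated chain carbon bound to an aromatic nitrogen. The two measured steps of the same kind are a 2.3-fold lower number from compound 1 to compound 2 (0.35 log units; beyond the scatter) and a 1.4-fold lower number from compound 1 to compound 3 (0.15 log units; within the scatter), so placing an aryl group on that carbon has at most modestly lowered the number. Pyridin-4-yl carries a hydrogen-bond acceptor that neither measured aryl group has, so the two steps give only an outline. A small lowering, or no change beyond the scatter, is expected for compound 4: a 1.4-fold lower number from compound 1 to compound 4 (0.13 log units; within the scatter). The estimate for compound 4 is 200 nM, between 90 nM and 450 nM.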

Compound 4, half-maximal inhibitory concentration: 5630 nM
Estimate against measurement, compound 4: 28-fold (1.45 log units) below; the measured number lies above the stated range.
By their numbers in this assay, from the lowest: compounds 2, 3 and 1 (each within the scatter of the next, the first and the last beyond it); then compound 4.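

In this assay, the saturated chain carbon bound to an aromatic nitrogen responds to which aryl group it carries, not merely to the presence of one. Pyridin-4-yl gives a 21-fold higher number from compound 1 to compound 4 (1.32 log units; beyond the scatter), and the comparison with the halogenated aryl groups gives a 30-fold higher number from compound 3 to compound 4 (1.47 log units; beyond the scatter) and a 47-fold higher number from compound 2 to compound 4 (1.67 log units; beyond the scatter). No measurement shown accounts for this loss. Open, from the compounds shown here alone, is whether the ring nitrogen itself or its placement matters: unsubstituted phenyl, pyridin-3-yl or pyridin-2-yl on the same carbon would separate the two. Also open, going by these compounds, is how a saturated amine such as piperidin-4-yl would read.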